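Changing the aryl ketone in a trimethoxyphenyl triazolothiadiazine series

The compounds below may be only part of what the source reports. "The series", "measured", "known", "first", "only" and "open" are said of these compounds alone.

This account follows two measured compounds and one not yet measured, all sharing a core built around a trimethoxyphenyl group, a furanyl group and an aryl ketone, and all read in a functional assay on A549 cells (Homo sapiens) for cytotoxicity, read by MTT assay, with a stated time of 48 h; on this read-out lower numbers stand for stronger inhibition and higher numbers for weaker inhibition. Compound 1 `COc1cc(-c2nnc3n2NC(c2ccco2)C(C(=O)c2ccc(Cl)cc2)S3)cc(OC)c1OC` gives 51400 nM in this assay. Compound 2 `COc1cc(-c2nnc3n2NC(c2ccco2)C(C(=O)c2cccc(Br)c2)S3)cc(OC)c1OC` gives 36900 nM in this assay, the lowest of the two numbers shown, though the step of a 1.4-fold lower number from compound 1 to compound 2 (0.14 log units; within the scatter) sits within the scatter, so the two compounds cannot be ranked against each other.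

Compound 3 `COc1cc(-c2nnc3n2NC(c2ccco2)C(C(=O)c2ccc(-c4ccccc4)cc2)S3)cc(OC)c1OC` differs from compound 2 in one place: 4-phenylphenyl in place of 3-bromophenyl on a carbonyl carbon. Among the measured compounds shown here, the only measured step that touches this position is the one from compound 1 to compound 2, which exchanged one halogenated phenyl for another on the same carbonyl carbon and stayed within the scatter. That step says little about a larger aryl group, so the expectation rests on a single, flat comparison. A step of a 1.2-fold lower number from compound 2 to compound 3 (0.06 log units; within the scatter) is therefore expected, with no clear direction beyond the scatter. Compound 3 is estimated at 32000 nM in this assay, with a range from 12000 nM to 85000 nM.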

Compound 3, half-maximal inhibitory concentration: > 100000 nM
Compound 3: a limit, no number; the forecaster's own chance of this, stated with the estimate: 15%; middle value at least 3.1-fold (0.49 log units) away from the limit.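

Compound 3 stands at a limit of the assay rather than at a number in this assay: the limit of > 100000 nM in this assay, at which 1 of the 3 values shown sits. The earlier exchange of one halogenated phenyl for another gave a 1.4-fold lower number from compound 1 to compound 2 (0.14 log units; within the scatter), but 4-phenylphenyl in place of 3-bromophenyl on the same carbonyl carbon gives an at least 2.7-fold higher number from compound 2 to compound 3 (0.43 log units; beyond the scatter), so this position is not indifferent to every aryl group and the change weakens the read-out by more than the scatter. Among the compounds shown here, the other comparison, phenyl in place of chloro on an aromatic carbon, gives an at least 1.9-fold higher number from compound 1 to compound 3 (0.28 log units; that floor lies within the scatter); its floor lies within the scatter, so this step alone does not separate the two compounds, and only the step from the bromophenyl compound shows the weakening.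

With only three aryl groups shown, the compounds leave open whether the change in the read-out follows from the second phenyl ring itself or would also appear with another group on the same ring, such as a methoxy group, an amine or a carboxylic acid. They also leave open how a plain unsubstituted phenyl or a pyridine ring would read on this carbonyl carbon.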